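The compounds below may be only part of what the source reports. "The series", "measured", "known", "first", "only" and "open" are said of these compounds alone.

Working notes on the bis-heteroaryl amidine series.

Of the compounds shown here, two have numbers so far. Compound 1 `N=C(N)c1ccc(-c2ccc(-c3cc(Cl)cc(Cl)c3)s2)s1` carries a pair of fused-free five-membered sulfur rings and a dichlorophenyl end; in a functional assay on cells (Panel NCI-60 (60 carcinoma cell lines), Homo sapiens) for inhibition, read by sulforhodamine B assay, with a stated time of 48 h (a higher number here means a weaker inhibitor of growth, a lower number a stronger inhibitor of growth), compound 1 gives 1940 nM. Compound 2 `COc1ccc(-c2ccc(-c3ccc(C(=N)N)o3)o2)cc1` keeps the amidine end but has oxygen rings and a methoxyphenyl end; in this assay compound 2 gives 1740 nM. The two values lie within the usual scatter of each other, so nothing can be said about an order between compound 1 and compound 2.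

The next compound to be measured is compound 3 `N=C(N)c1ccc(-c2ccc(-c3ccccc3)o2)o1`. The change from compound 2 is hydrogen in place of methoxy on an aromatic carbon. Among the measured compounds shown here, no step between measured compounds shows what removing a methoxy does, so no direction can be read from the data. The expectation is a step of no more than the scatter, if anything a slightly higher number, expressed as a 1.4-fold higher number from compound 2 to compound 3 (0.16 log units; within the scatter). Compound 3 is therefore estimated at 2500 nM, with a range from 1000 nM to 6000 nM, pending the result.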

Compound 3, concentration for 50% growth inhibition: 2400 nM
Compound 3: the middle estimate sits 1.0-fold (0.02 log units) above what was measured, and the stated range covers the measured number.
By their numbers in this assay, from the lowest: compounds 2, 1 and 3 (each within the scatter of the next).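

Among the compounds shown here, the step is the first that isolates a single change: hydrogen in place of methoxy on an aromatic carbon of a six-membered aromatic ring of carbon only, para to a large group. In this assay the change gives a 1.4-fold higher number from compound 2 to compound 3 (0.14 log units; within the scatter) and so lies within the scatter, which means that losing the methoxy, with its 2 heavy atoms and 1 hydrogen-bond acceptor, does not separate these two compounds at this place. Nothing on hand gives any measured account of this result.

For the compounds shown here, a single replacement at one place says little about the place as a whole: an amine, a carboxylic acid, a fluorine atom or a longer chain such as butoxy on the same aromatic carbon could still give a step beyond the scatter, and the series so far holds no such compound. On these data alone, the reading also stays confined to the pair with the oxygen rings, and whether the same replacement gives a similar step on the sulfur rings of compound 1 remains open, as that compound has no partner differing from it in one place.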